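The compounds below may be only part of what the source reports. "The series", "measured", "known", "first", "only" and "open" are said of these compounds alone.

Measured in a functional assay on MDA-MB-231 cells (Homo sapiens) for inhibition, read by MTT assay, with a stated time of 72 h (on this read-out lower numbers stand for stronger inhibition and higher numbers for weaker inhibition), so far:
Compound 1 `Cc1ccc(C(C)C)c(OCc2cn(-c3ccccc3)nn2)c1` gives 45100 nM
Compound 2 `Cc1ccc(C(C)C)c(OCc2cn(-c3ccc(F)cc3)nn2)c1` gives 32600 nM
Compound 3 `Cc1cccc(-n2cc(COc3cc(C)ccc3C(C)C)nn2)c1` gives 31300 nM

These three numbers sit close together, and no order can be read among them. Compound 3 stands within the scatter of both neighbours, as the step of a 1.0-fold lower number from compound 2 to compound 3 (0.02 log units; within the scatter) and the step of a 1.4-fold lower number from compound 1 to compound 3 (0.16 log units; within the scatter) show.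

Compound 4 `Cc1ccc(C(C)C)c(OCc2cn(-c3ccccc3C)nn2)c1` has not been measured yet. It has the same atoms as compound 3, joined differently: 2-methylphenyl in place of 3-methylphenyl on an aromatic nitrogen, next to the ring nitrogen (2-methylphenyl in place of 3-methylphenyl on an aromatic nitrogen).

Among the compounds with values here, no measured compound carries the 2-methylphenyl group, so the data give no direct guide to this change. The nearest evidence is the step that adds a methyl to the phenyl group, a 1.4-fold lower number from compound 1 to compound 3 (0.16 log units; within the scatter), together with the step that adds a fluoro, a 1.4-fold lower number from compound 1 to compound 2 (0.14 log units; within the scatter). Both stay within the scatter, so changes on this phenyl group have so far done little in this assay and a clear shift would be a surprise.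

The expected step is a 1.1-fold higher number from compound 3 to compound 4 (0.02 log units; within the scatter), which means none beyond the scatter. The estimate for compound 4 is 33000 nM, with an expected range from 17000 nM to 65000 nM.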

Compound 4, half-maximal inhibitory concentration: 10500 nM
Beside the measured number, compound 4's estimate is 3.1-fold (0.50 log units) above it; the measured number lies below the stated range.
By their numbers in this assay, from the lowest: compound 4; then compounds 3, 2 and 1 (each within the scatter of the next).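

Where the methyl sits on the phenyl group turns out to matter in this assay: moving it to give the 2-methylphenyl group produces a modest change (a 3.0-fold lower number from compound 3 to compound 4 (0.47 log units; beyond the scatter)), and this is the first step here to go beyond the scatter, even though the two compounds have the same atoms. Adding a methyl to the plain phenyl group therefore can count, but only in this placement, as the 2-methylphenyl compound shows (a 4.3-fold lower number from compound 1 to compound 4 (0.63 log units; beyond the scatter)), while the 3-methylphenyl compound stayed within the scatter of compound 1; the 2-methylphenyl group also gives a modest gain over the 4-fluorophenyl group (a 3.1-fold lower number from compound 2 to compound 4 (0.49 log units; beyond the scatter)). Nothing measured here explains why this one placement stands apart.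

The compounds shown leave open whether the gain belongs to methyl alone or would persist with another group in its place, such as an ethyl group, a chlorine atom or a carboxylic acid. They also leave open whether a second methyl on the phenyl group would add to the step seen with the first, or would take it away.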